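From fluoro to cyano on an aromatic ring

This account rests on a few compounds, and the source may have more. Where it says the series, first, only, none or still open, it means among the compounds named here.

In a functional assay on B16 cells (Mus musculus) for antiproliferative activity, read by MTT assay, with a stated time of 24 h (a lower number here means a stronger inhibitor, a higher number a weaker inhibitor), compound 1 `COc1cc(OC)c(-c2coc3cc(OCC=C(C)C)ccc3c2=O)cc1OC` gives 1090 nM as its value. Compound 2 `COc1cc(OC)c(-c2coc3cc(OCc4ccc(F)cc4)ccc3c2=O)cc1OC` gives 1120 nM and so stands level with compound 1 within the scatter. Compound 3 `COc1cc(OC)c(-c2coc3cc(OCc4ccc(C#N)cc4)ccc3c2=O)cc1OC` has not yet been measured. It differs from compound 2 by cyano in place of fluoro on an aromatic carbon in one place, with cyano in place of fluoro on an aromatic carbon, para to a large group. Among the compounds with values here, only one measured step is available, and it concerns a different swap, 4-fluorophenyl in place of 2-methylprop-1-en-1-yl. That step, a 1.0-fold higher number from compound 1 to compound 2 (0.01 log units; within the scatter), stayed small. Within the data shown here, no measured step covers cyano itself, so the data point in no direction, and no change beyond the scatter is expected in this assay here. The expected step is a 1.1-fold lower number from compound 2 to compound 3 (0.03 log units; within the scatter) and would be small. Compound 3 is estimated at 1050 nM, with an expected range from 420 nM to 2600 nM for the measurement.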

Compound 3, half-maximal inhibitory concentration: 7000 nM
Estimate against measurement, compound 3: 6.7-fold (0.82 log units) below; measured number outside the range, above it.
By their numbers in this assay, from the lowest: compounds 1 and 2 (each within the scatter of the next); then compound 3.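

In this assay, cyano in place of fluoro on the aromatic carbon para to a large group gives a 6.3-fold higher number from compound 2 to compound 3 (0.80 log units; beyond the scatter) and so a weaker inhibitor, which shows that the group on this carbon can matter. Compounds 1 and 2 stood level despite their different end groups, and that had hidden this sensitivity; the 4-cyanobenzyl end group also separates from the chain of compound 1, with a 6.4-fold higher number from compound 1 to compound 3 (0.81 log units; beyond the scatter) in the same direction. No measurement here explains why cyano weakens the antiproliferative effect.

As far as these compounds go, with only fluoro and cyano compared on this carbon, it remains open whether the loss is particular to cyano. A chloro, a methoxy or a carboxylic acid at the same place would show whether other groups behave like fluoro or like cyano.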